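Swapping the Aryl Group on the Alkyne of Compound 2

This account rests on a few compounds, and the source may have more. Where it says the series, first, only, none or still open, it means among the compounds named here.

Among the compounds with values here, compound 2 `CNC(=O)[C@@]12C[C@@H]1[C@@H](n1cnc3c(NC)nc(C#Cc4cccc(C(F)(F)F)c4)nc31)[C@H](O)[C@@H]2O` is one of two compounds so far measured in an assay on CHO cells for displacement of a labelled ligand from adenosine receptor A1 (Homo sapiens), read by scintillation counting, with a stated time of 60 min, tested at 10 uM; a lower number here means less inhibition, a higher number more inhibition at the concentration tested (going by the name of the read-out). Compound 2 gives 10%, the lowest of the two numbers shown, though within the scatter of compound 1 `CNC(=O)[C@@]12C[C@@H]1[C@@H](n1cnc3c(NC)nc(C#Cc4ccc(-c5ccccc5)cc4)nc31)[C@H](O)[C@@H]2O`, which gives 18%. Within the data shown here, the single measured step, a number 8 percentage points lower from compound 1 to compound 2 (within the scatter), exchanges one aryl group for another on the triple-bonded carbon without moving the read-out beyond the scatter. Compound 3 `CNC(=O)[C@@]12C[C@@H]1[C@@H](n1cnc3c(NC)nc(C#Cc4ccc(CO)cc4)nc31)[C@H](O)[C@@H]2O` has not yet been measured in this assay. It differs from compound 2 in one place: 4-(hydroxymethyl)phenyl in place of 3-(trifluoromethyl)phenyl on a triple-bonded carbon. Among the measured compounds shown here, no measured compound carries a hydroxymethyl group, so the one step bears on this change only in a general way: it shows that replacing the aryl group on the triple-bonded carbon left this assay essentially unchanged, because a number 8 percentage points lower from compound 1 to compound 2 (within the scatter) lay within the scatter. On that basis compound 3 is expected to sit near compound 2, with a step of a number 2 percentage points higher from compound 2 to compound 3 (within the scatter) and none beyond the scatter. The estimate for compound 3 is 12%, expected to fall between 0% and 30%.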

Compound 3, a percentage reported as inhibition, at one concentration (the size of the read-out at that concentration, not a potency): 16%
Estimate against measurement, compound 3: 4 percentage points below; measured number inside the range.
By their numbers in this assay, from the lowest: compounds 2, 3 and 1 (each within the scatter of the next).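

In this assay, the change from 3-(trifluoromethyl)phenyl to 4-(hydroxymethyl)phenyl on a triple-bonded carbon gives a number 6 percentage points higher from compound 2 to compound 3 (within the scatter), and hydroxymethyl in place of phenyl on an aromatic carbon gives a number 2 percentage points lower from compound 1 to compound 3 (within the scatter). Neither of the two earlier compounds carries a hydrogen-bond donor or acceptor in this group, whereas 4-(hydroxymethyl)phenyl is counted with one of each, and the read-out still does not separate compound 3 from either compound, so the three aryl groups now seen at this position cannot be told apart in this assay. Nothing available explains this lack of separation, and no independent measurement bears on it.

The compounds shown leave open whether any group on this triple-bonded carbon can move the read-out beyond the scatter, for instance an aryl ring carrying an amine or a carboxylic acid, a longer chain ending in a hydroxyl in place of hydroxymethyl, or a group with no aromatic ring at all. They also leave open how the read-out would respond at any other concentration, as every number here comes from a single one.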